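Adding a Trifluoromethyl Group to Compound 3

This account rests on a few compounds, and the source may have more. Where it says the series, first, only, none or still open, it means among the compounds named here.

Compound 1, `O=S(=O)(NCCCCNCc1ccc(Br)cc1)c1cc(C(F)(F)F)cc(C(F)(F)F)c1`, in a functional assay on BXPC-3 cells (Homo sapiens) for inhibition, read by MTT assay, with a stated time of 72 h (a lower number here means a stronger inhibitor of growth, a higher number a weaker inhibitor of growth), compound 1 gives 1700 nM.
Compound 2, `O=S(=O)(NCCCNCc1ccc(Cl)cc1)c1cc(C(F)(F)F)cc(C(F)(F)F)c1`, gives 1600 nM.
Compound 3, `O=S(=O)(NCCCNCc1cccc(Cl)c1)c1cc(C(F)(F)F)cc(C(F)(F)F)c1`, gives 3800 nM.

Compound 3 stands highest of the three numbers, so it is the weakest growth inhibitor here: a 2.2-fold higher number from compound 1 to compound 3 (0.35 log units; beyond the scatter), and a 2.4-fold higher number from compound 2 to compound 3 (0.38 log units; beyond the scatter). Compound 4, `O=S(=O)(NCCCNCc1ccc(Cl)c(C(F)(F)F)c1)c1cc(C(F)(F)F)cc(C(F)(F)F)c1`, differs from compound 3 by 4-chloro-3-(trifluoromethyl)phenyl in place of 3-chlorophenyl on a saturated chain carbon bound to an amine nitrogen. Among the compounds with values here, the change brings back the 4-chlorophenyl pattern of compound 2 and adds a trifluoromethyl; only the modest step of a 2.4-fold higher number from compound 2 to compound 3 (0.38 log units; beyond the scatter) bears on it, and no measured pair shows what the trifluoromethyl does. A modest lowering is therefore expected, roughly undoing that step, with wide uncertainty: a 2.1-fold lower number from compound 3 to compound 4 (0.32 log units; beyond the scatter). Compound 4 is estimated at 1800 nM, between 700 nM and 4500 nM.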

Compound 4, concentration for 50% growth inhibition: 7800 nM
For compound 4 the middle estimate is 4.3-fold (0.64 log units) below the measured one; measured number above the stated range.
By their numbers in this assay, from the lowest: compounds 2 and 1 (each within the scatter of the next); then compound 3; then compound 4.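

Trifluoromethyl in place of hydrogen on an aromatic carbon gives a 4.9-fold higher number from compound 2 to compound 4 (0.69 log units; beyond the scatter) in this assay and so points to weaker growth inhibition, the first direct reading of this group at this position. Replacing 3-chlorophenyl with 4-chloro-3-(trifluoromethyl)phenyl gives a 2.1-fold higher number from compound 3 to compound 4 (0.31 log units; beyond the scatter) even though the chlorine pattern of the stronger compound 2 returns, so that earlier gain does not carry over once trifluoromethyl is present. No measurement here offers an explanation for this. On these data alone, it remains open whether a methyl or methoxy group on that aromatic carbon would raise the number too, and whether trifluoromethyl would act alike on the chain of compound 1.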